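Replacing the pyridazine with a fluoropyridine on the cyclic carbamate

This account rests on a few compounds, and the source may have more. Where it says the series, first, only, none or still open, it means among the compounds named here.

Compound 1 `O=C1O[C@]2(CC[C@H](CNc3cnn(-c4ccccc4F)c3)CC2)CN1c1cccnn1`: 0.1 nM
Compound 2 `O=C1O[C@]2(CC[C@H](CNc3cnn(-c4ccccc4F)c3)CC2)CN1c1ccnnc1`: 0.2 nM

In a functional assay for antagonist activity at Neuropeptide Y receptor type 5 (Homo sapiens) (on this read-out lower numbers stand for stronger inhibition and higher numbers for weaker inhibition), compound 1 gives 0.1 nM, and compound 2 gives 0.2 nM. Compound 2 has the higher of the two numbers, but the step of a 2.0-fold higher number from compound 1 to compound 2 (0.30 log units; within the scatter) lies within the scatter, so the two cannot be ranked. Compound 3 `O=C1O[C@]2(CC[C@H](CNc3cnn(-c4ccccc4F)c3)CC2)CN1c1cccnc1F` differs from compound 2 by 2-fluoropyridin-3-yl in place of pyridazin-4-yl on an amide-type nitrogen in a ring. Among the measured compounds shown here, only that one step, which swapped one ring for another at the same place, bears on this change, and it stayed within the scatter; for compound 3 the expectation is therefore a number close to compound 2, estimated at 0.3 nM with a range from 0.08 nM to 1.2 nM, meaning a step of a 1.5-fold higher number from compound 2 to compound 3 (0.18 log units; within the scatter).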

Compound 3, inhibition constant: 0.1 nM
Beside the measured number, compound 3's estimate is 3.0-fold (0.48 log units) above it; the range from low to high includes it.
By their numbers in this assay, from the lowest: compounds 1, 3 and 2 (each within the scatter of the next).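

In this assay both a 2.0-fold lower number from compound 2 to compound 3 (0.30 log units; within the scatter) and no change at the digits printed from compound 1 to compound 3 (within the scatter) leave the three compounds impossible to rank. The amide-type nitrogen of the five-membered ring can therefore carry a six-membered aromatic ring with 1 hetero atom and a fluorine, as well as one with 2 hetero atoms, and the numbers stay equally low. No evidence is available on what lies behind this result. A plain pyridin-3-yl group at this place would show what the fluorine contributes. On these data alone, whether a small non-aromatic group, such as methyl or a simple amine, would fit here also remains open.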